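Adding a Furanylmethyl Group to the Anilino Nitrogen

The source may report more compounds than this note shows. Statements on the series, on what has been measured and on what is new or still open speak of the compounds shown alone.

Measured compounds:
compound 1 `CC1(C)Oc2ccc(C#N)cc2[C@H](Nc2ccccc2)[C@H]1O`: 1200 nM
compound 2 `CCOC(=O)CN(c1ccc(F)cc1)[C@H]1c2cc(C#N)ccc2OC(C)(C)[C@@H]1O`: > 30000 nM

Both were tested in a functional assay (aorta) with Rattus norvegicus as the target; on this read-out lower numbers stand for stronger inhibition and higher numbers for weaker inhibition. Among the measured compounds shown here, compound 1 gives 1200 nM in this assay, the only plain number among the values shown. For compound 2 the assay reports only a limit, > 30000 nM, so no number is known for it. This limit is the limit of > 30000 nM in this assay, at which 1 of the 2 values shown sits. For the measured compounds named here, no step between compounds that differ in a single place is available, so the two values can only be set side by side: compound 1 has a measured number, compound 2 does not.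

Compound 3 `CC1(C)Oc2ccc(C#N)cc2[C@H](N(Cc2ccco2)c2ccccc2)[C@H]1O` has not yet been measured. It differs from compound 1 by (furan-2-yl)methyl in place of hydrogen on a nitrogen on an aromatic ring. Turning the nitrogen from a hydrogen-bearing one into a fully substituted one is expected to cost potency, and the step of a 6.7-fold higher number from compound 1 to compound 3 (0.82 log units; beyond the scatter) is expected to be a weakening beyond the scatter. Compound 3 is therefore expected to give about 8000 nM, somewhere between 2000 nM and 30000 nM.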

Compound 3, half-maximal inhibitory concentration: 12000 nM
Compound 3: the middle estimate sits 1.5-fold (0.18 log units) below what was measured, within the range that was stated.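

In this assay, among the compounds shown here, this step is the first direct reading of what a change on the anilino nitrogen does: (furan-2-yl)methyl in place of hydrogen gives a 10-fold higher number from compound 1 to compound 3 (1.00 log units; beyond the scatter). The change weakens inhibition, yet compound 3 still gives a plain number, 12000 nM, so the nitrogen can carry this larger group without the activity falling out of measurable range. Nothing shown here gives a cause for the step.

With only this one substituent, the compounds shown cannot separate the effect of losing the hydrogen on the nitrogen from the effect of the furan ring itself. A simple methyl group on the same nitrogen would help to tell these two apart, while a benzyl group would show whether the furan ring matters.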